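The Same Chloro Step Carried onto a Second Core

The source may hold more compounds than are shown below. What is called first, only, known or untested is meant among the compounds shown, and "the series" means these compounds.

Compound 1, `CC1=C(C(=O)Nc2ccc(F)cc2)C(c2ccc([N+](=O)[O-])cc2)N=C(SCc2ccccc2)N1`, gives 27.3% in a functional assay on the whole organism (artery, strain albino) with Rattus norvegicus as the target, with a stated time of 720 min, at a dose of 10 mg/kg by the oral route; a higher number here means more inhibition at the dose given (going by the name of the read-out), a lower number less inhibition. Compound 2, `CC1=C(C(=O)Nc2ccc(F)cc2)C(c2ccc([N+](=O)[O-])cc2)N=C(SCc2ccccc2Cl)N1`, carries chloro in place of hydrogen on an aromatic carbon and gives 13.9% in this assay, so that a number 13.4 percentage points lower from compound 1 to compound 2 (beyond the scatter). Compound 3, `COc1ccc(C2N=C(SCc3ccccc3)NC(C)=C2C(=O)Nc2ccc(Br)cc2)cc1`, rests on a different core; the difference between the two cores is not broken down here. In this assay compound 3 gives 7.2%, the lowest of the three numbers, with compound 2 within the scatter of it and compound 1 beyond it. Compound 4, `COc1ccc(C2N=C(SCc3ccccc3Cl)NC(C)=C2C(=O)Nc2ccc(Br)cc2)cc1`, is compound 3 with chloro in place of hydrogen on an aromatic carbon, the same change as that from compound 1 to compound 2. For the measured compounds named here, because compound 3 already stands at 7.2%, little room remains for a step of the earlier size, and the single precedent is a modest one. Compound 4 is therefore expected to give 3%, between -6% and 13%, an expected step of a number 4.2 percentage points lower from compound 3 to compound 4 (within the scatter) beside the earlier a number 13.4 percentage points lower from compound 1 to compound 2 (beyond the scatter).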

Compound 4, a percentage reported as inhibition, in the whole organism at one dose (the size of the read-out at that dose, not a potency): 10.8%
Beside the measured number, compound 4's estimate is 7.8 percentage points below it; the measured number falls inside the stated range.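

In this assay, chloro in place of hydrogen on the core of compound 3 gives a number 3.6 percentage points higher from compound 3 to compound 4 (within the scatter), so on this core the step cannot be told from no change. The change therefore does not carry over from one core to the other at the same size: the same change on two cores in this assay, a number 13.4 percentage points lower (beyond the scatter) from compound 1 to compound 2 and a number 3.6 percentage points higher (within the scatter) from compound 3 to compound 4, 17 percentage points apart, beyond the scatter of two such steps. This does not show which part of the difference between the cores accounts for the gap, and two pairs set no rule for the series.

The compounds shown leave open how an amine or a carboxylic acid in place of the chloro would behave on either core. They also leave open whether the 2-chlorobenzyl group would give either step on any further core.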